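The source may hold more compounds than are shown below. What is called first, only, known or untested is meant among the compounds shown, and "the series" means these compounds.

Values so far in a functional assay on C8166 cells (Homo sapiens) for cytotoxicity, read by MTT assay (on this read-out lower numbers stand for higher toxicity in this test and higher numbers for lower toxicity in this test), are these
Compound 1 `Cc1cc(S(N)(=O)=O)ccc1NC(=O)COc1ccc(Cl)cc1NC(=O)c1cccc(F)c1` gives 243000 nM
Compound 2 `COc1ccc(C(=O)Nc2cc(Cl)ccc2OCC(=O)Nc2ccc(S(N)(=O)=O)cc2C)cc1` gives 69500 nM
Compound 3 `Cc1cc(S(N)(=O)=O)ccc1NC(=O)COc1ccc(Cl)cc1NC(=O)c1cc(Cl)ccc1Cl` gives 42100 nM

Compound 3 stands at the low end of these numbers, level with compound 2 and clear of compound 1. Compound 4 `Cc1cc(S(N)(=O)=O)ccc1NC(=O)COc1ccc(Cl)cc1NC(=O)c1cc(Cl)cc(Cl)c1` has the same atoms joined differently, with 3,5-dichlorophenyl in place of 2,5-dichlorophenyl on a carbonyl carbon. Every measured step changes the group at that same place. They are a 3.5-fold lower number from compound 1 to compound 2 (0.54 log units; beyond the scatter), then a 5.8-fold lower number from compound 1 to compound 3 (0.76 log units; beyond the scatter), and finally a 1.7-fold lower number from compound 2 to compound 3 (0.22 log units; within the scatter). Both modest steps start from the 3-fluorophenyl group of compound 1, and none of the three moves a chlorine around the ring. The last step shows that a change of group there need not shift the number beyond the scatter. Compound 4 keeps both chlorines of compound 3 at 42100 nM, so no step beyond the scatter is expected in this assay. The expected change is a 1.4-fold higher number from compound 3 to compound 4 (0.15 log units; within the scatter), with the direction left open. For compound 4 the estimate is 60000 nM, with an expected range from 22000 nM to 170000 nM.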

Compound 4, half-maximal cytotoxic concentration: 72400 nM
For compound 4 the middle estimate is 1.2-fold (0.08 log units) below the measured one; measured number inside the range.
By their numbers in this assay, from the lowest: compounds 3, 2 and 4 (each within the scatter of the next); then compound 1.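

In this assay, among these compounds, the first change here that only rearranges the same atoms, 3,5-dichlorophenyl in place of 2,5-dichlorophenyl on the carbonyl carbon, gives a 1.7-fold higher number from compound 3 to compound 4 (0.24 log units; within the scatter) and so stays within the scatter. Compound 4 also stays level with the 4-methoxyphenyl group of compound 2, at a 1.0-fold higher number from compound 2 to compound 4 (0.02 log units; within the scatter) and, with a 3.4-fold lower number from compound 1 to compound 4 (0.53 log units; beyond the scatter) as a third step beyond the scatter from compound 1, the 3-fluorophenyl group alone stands apart among these four compounds. No evidence is available on what lies behind these numbers.

As far as these compounds go, it remains open whether a phenyl group with a single chlorine would sit with the dichlorophenyl compounds or with compound 1. From the compounds shown here alone, it is equally open how an amine or a carboxylic acid on this phenyl ring would read in this assay against these four compounds.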